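This account rests on a few compounds, and the source may have more. Where it says the series, first, only, none or still open, it means among the compounds named here.

Compound 1 `Cc1cnc(Nc2ccc(C(C)C)cc2)nc1Nc1nc2ccccc2s1` was tested in a functional assay on HeLa cells (Homo sapiens) for antiproliferative activity, read by MTT assay, with a stated time of 48 h; on this read-out lower numbers stand for stronger inhibition and higher numbers for weaker inhibition. In this assay compound 1 gives only a limit, > 50000 nM, which is the limit of > 50000 nM in this assay, at which 1 of the 3 values shown sits, and not a measured number. Two further compounds share the core of compound 1 but differ from it in more than one place: compound 2 `NS(=O)(=O)c1ccc(Nc2ncc(F)c(Nc3nc4ccccc4s3)n2)cc1` and compound 3 `NS(=O)(=O)c1ccc(Nc2ncc(F)c(Nc3nc4ccc(Cl)cc4s3)n2)cc1`. In this assay compound 2 gives 4520 nM, and compound 3 gives 8770 nM. Going by the values given here, the only single step measured between them, a 1.9-fold higher number from compound 2 to compound 3 (0.29 log units; within the scatter), concerns a chloro on a different ring and says nothing about the change now in question. The step to compound 4 `Cc1cnc(Nc2ccc(F)cc2)nc1Nc1nc2ccccc2s1` is this: fluoro in place of isopropyl on an aromatic carbon. Among the compounds with values here, no measured pair shows what this exchange does on its own, so the two numbered values of compound 2 and compound 3 serve only to show that the core can reach measurable inhibition when the outer ring is altered. Whether a fluoro on the ring where compound 1 carries an isopropyl will do the same is open. The expectation for compound 4 is therefore broad and leans toward weak inhibition, with an estimated 30000 nM in a range from 5000 nM to 100000 nM. That estimate amounts to an expected step of an at least 1.6-fold lower number from compound 1 to compound 4 (0.22 log units; that floor lies within the scatter), held with little confidence.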

Compound 4, half-maximal inhibitory concentration: > 50000 nM
Compound 4: only a limit was reported; the forecaster's own chance of this, stated with the estimate: 50%; middle value at least 1.6-fold (0.22 log units) away from the limit.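

Compound 1 and compound 4 both stop at a limit rather than a measured number in this assay, so no step can be read between them: the limit of > 50000 nM in this assay, at which 2 of the 4 values shown sit.

The compounds shown leave open what fluoro in place of isopropyl does on its own, and which difference from compound 2 and compound 3 matters for reaching measurable inhibition.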